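Swapping hydroxy for nitro on the aryl ketone

The compounds below may be only part of what the source reports. "The series", "measured", "known", "first", "only" and "open" are said of these compounds alone.

Measured in a functional assay on A549 cells (Homo sapiens) for antiproliferative activity, read by sulforhodamine B assay, with a stated time of 48 h; a lower number here means a stronger inhibitor, a higher number a weaker inhibitor:
- compound 1 `COc1ccc(C(=O)/C=C\Nc2ccc(-c3nc4cc(OC)c(OC)c(OC)c4s3)cc2C)cc1[N+](=O)[O-]`: 9100 nM
- compound 2 `COc1cc(OC)c2sc(-c3ccc(N/C=C\C(=O)c4ccc(OC)c([N+](=O)[O-])c4)cc3)nc2c1`: 5800 nM
- compound 3 `COc1ccc(C(=O)/C=C\Nc2ccc(-c3nc4cc(OC)c(OC)c(OC)c4s3)cc2)cc1O`: 23000 nM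

At 23000 nM, compound 3 has the highest number of the three, so it is the weakest inhibitor here. Compound 4 `COc1ccc(C(=O)/C=C\Nc2ccc(-c3nc4cc(OC)c(OC)c(OC)c4s3)cc2)cc1[N+](=O)[O-]` puts nitro in place of hydroxy on an aromatic carbon, turning 3-hydroxy-4-methoxyphenyl into 4-methoxy-3-nitrophenyl (nitro in place of hydroxy on an aromatic carbon). Going by the values given here, no measured pair isolates this change. However, both nitro compounds give lower numbers than compound 3: compound 1 at 9100 nM and compound 2 at 5800 nM, although their cores differ from that of compound 4. A moderate gain beyond the scatter is therefore expected, an estimated 3.1-fold lower number from compound 3 to compound 4 (0.49 log units; beyond the scatter). For compound 4 the estimated value is 7500 nM, with an expected range of 2800 nM to 18000 nM.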

Compound 4, half-maximal inhibitory concentration: 21200 nM
The estimate for compound 4 lay 2.8-fold (0.45 log units) below the measured number, and the stated range ends below it.
By their numbers in this assay, from the lowest: compounds 2 and 1 (each within the scatter of the next); then compounds 4 and 3 (each within the scatter of the next).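

Nitro and hydroxy on this aromatic carbon cannot be told apart here: the swap gives a 1.1-fold lower number from compound 3 to compound 4 (0.04 log units; within the scatter) and so leaves the number unchanged. The gaps between the nitro compounds lie elsewhere, since methoxy in place of hydrogen on an aromatic carbon gives a 3.7-fold higher number from compound 2 to compound 4 (0.56 log units; beyond the scatter) and hydrogen in place of methyl gives a 2.3-fold higher number from compound 1 to compound 4 (0.37 log units; beyond the scatter) among compounds that all carry nitro. No measurement shown here accounts for these steps.

From the compounds shown here alone, whether an amine or a fluorine on this carbon would give a different number stays open. So does whether the methoxy and methyl steps would hold with hydroxy in place of nitro.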